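The source may hold more compounds than are shown below. What is called first, only, known or untested is meant among the compounds shown, and "the series" means these compounds.

Measured so far:
Compound 1, `COc1ccc(CNc2nc([Se]C)nc3ccccc23)cc1`, gives 73600 nM in a functional assay on HT-29 cells (Homo sapiens) for cytotoxicity, read by MTT assay, with a stated time of 72 h; on this read-out lower numbers stand for stronger inhibition of growth and higher numbers for weaker inhibition of growth.
Compound 2, `Sc1nc(NCc2ccccc2)c2ccccc2n1`, gives 10100 nM in this assay.

Compound 2 holds the lowest of the two numbers in this assay; its nearest neighbour is compound 1, whose number is higher by an amount beyond the usual scatter. Compound 1 differs from compound 2 in more than one place, so the two values alone do not tell which of those differences carries the gap.

Compound 3, `COc1ccc(CNc2nc(S)nc3ccccc23)cc1`, differs from compound 2 in a single way: methoxy in place of hydrogen on an aromatic carbon. Going by the values given here, no measured pair isolates this change, so the size of the step in this assay is open. Compound 1 carries the same methoxy group and gives 73600 nM, but it also carries a different group on the shared core, so its value is only a loose pointer toward a weaker number. On that basis a modest rise, not far beyond the scatter, is expected. For compound 3 the expected step is a 1.6-fold higher number from compound 2 to compound 3 (0.20 log units; within the scatter). Compound 3 is therefore estimated at 16000 nM, with a range from 5000 nM to 50000 nM.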

Compound 3, concentration for 50% growth inhibition: 6490 nM
Beside the measured number, compound 3's estimate is 2.5-fold (0.39 log units) above it, and the stated range covers the measured number.
By their numbers in this assay, from the lowest: compounds 3 and 2 (each within the scatter of the next); then compound 1.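

The methoxy group, on an aromatic carbon of the six-membered aromatic ring of carbon only and para to a large group, makes little measurable difference here: a 1.6-fold lower number from compound 2 to compound 3 (0.19 log units; within the scatter) in this assay. Going by these compounds alone, that pair gives the first isolated reading of this change, and it shows no step beyond the scatter on this scaffold when the sulfur atom stands on the shared core.

With the methoxy group present on both sides, the other place carries a large effect: an 11-fold lower number from compound 1 to compound 3 (1.05 log units; beyond the scatter). This single change therefore accounts for a far larger step than the methoxy change does, although nothing available here explains why the number moves so much at either place.

The step from compound 1 to compound 3 exchanges a group holding carbon and selenium for one sulfur atom, so the compounds shown cannot separate the part played by the selenium from that of the attached carbon, a question that a methylthio group would address directly. They also leave open how this assay responds to other groups on the same aromatic carbon, such as a chlorine atom, an amine or a longer chain like butoxy.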